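The compounds below may be only part of what the source reports. "The series", "measured", "known", "first", "only" and "open" are said of these compounds alone.

Measured compounds:
compound 1 `O=C(/C=C/c1ccc(OCCCCCO[N+](=O)[O-])c(O)c1)OCCCCCO[N+](=O)[O-]` — > 50000 nM
compound 2 `O=C(/C=C/c1ccc(OCCCCO[N+](=O)[O-])c(O)c1)OCCCCO[N+](=O)[O-]` — > 50000 nM
compound 3 `COc1cc(/C=C/C(=O)OCCCCCO[N+](=O)[O-])ccc1OCCCCCO[N+](=O)[O-]` — > 50000 nM

All three were tested in a functional assay on NCI-H1299 cells (Homo sapiens) for cytotoxicity, read by resazurin assay, with a stated time of 72 h; a higher number here means a weaker inhibitor, a lower number a stronger inhibitor. Compound 1 gives only a limit of the assay there, > 50000 nM, not a number. Compound 2 likewise gives only a limit, > 50000 nM. Compound 3 also reaches only a limit, > 50000 nM. The change from compound 1 to compound 3 is methyl in place of hydrogen on an oxygen on an aromatic ring; the size of its step, a step that the two limits leave unreadable from compound 1 to compound 3, cannot be read, because of the limit of > 50000 nM in this assay, at which 3 of the 3 values shown sit.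

Compound 4, `COc1cc(/C=C/C(=O)OCCCCO[N+](=O)[O-])ccc1OCCCCO[N+](=O)[O-]`, stands to compound 2 as compound 3 stands to compound 1: the change is methyl in place of hydrogen on an oxygen on an aromatic ring, the same change at the same place. The difference between the core of compound 2 and the core of compound 1 is not broken down here.

Because compound 2 sits at a limit, > 50000 nM, the step from compound 2 to compound 4 is expected to be a step that the limit leaves unreadable from compound 2 to compound 4, and is most likely unreadable again. Compound 4 is estimated at 100000 nM in this assay, with a strong chance that only a limit is reported.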

Compound 4, half-maximal inhibitory concentration: > 50000 nM
Compound 4: no number, only a limit; the forecaster's own chance of this, stated with the estimate: 85%; the middle value is on the limit's open side.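

In this assay compound 4 gives only a limit, > 50000 nM, not a number. The step from compound 2 to compound 4 therefore cannot be read, because neither end of it has a number: the limit of > 50000 nM in this assay, at which 4 of the 4 values shown sit. The compounds shown leave open whether hydroxy to methoxy makes any difference in this assay.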